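A few compounds are considered here, and "the series" means these few. Any claim that something is new, unique, unknown or untested is made for them only; others in the source may bear on it.

Working notes on the series.

Compound 1 `C=CC(=O)Nc1cc(N)nc(Sc2c(OC)nc(N3CCCCC3)nc2OC)n1` carries a piperidin-1-yl group on the core; in a functional assay on SK-BR-3 cells (Homo sapiens) for activation, read by Western blot (a higher number here means a weaker inhibitor, a lower number a stronger inhibitor), compound 1 gives 5000 nM. Compound 2 `C=CC(=O)Nc1cc(N)nc(Sc2c(OC)nc(N3CCN(C)CC3)nc2OC)n1` differs from compound 1 by 4-methylpiperazin-1-yl in place of piperidin-1-yl on an aromatic carbon. In this assay compound 2 gives 2000 nM, so the step of a 2.5-fold lower number from compound 1 to compound 2 (0.40 log units; beyond the scatter) is a modest gain in potency.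

Compound 3 `C=CC(=O)Nc1cc(N)nc(Sc2c(OCC)nc(N3CCCCC3)nc2OCC)n1` has the same piperidin-1-yl group but two ethoxy groups where compound 1 has two methoxy groups; the difference between the two cores is not broken down here. In this assay compound 3 gives 10000 nM. This is the highest of the three numbers, but the gap to compound 1 lies within the scatter, so no order between compound 3 and compound 1 can be claimed; only compound 2 stands clearly apart from compound 3.

Compound 4 `C=CC(=O)Nc1cc(N)nc(Sc2c(OCC)nc(N3CCN(C)CC3)nc2OCC)n1` is not yet measured. It differs from compound 3 by 4-methylpiperazin-1-yl in place of piperidin-1-yl on an aromatic carbon. This is the same kind of change as that from compound 1 to compound 2: the change itself is identical, but the place differs in that the entering group sits meta to two ethoxy groups in compound 4, whereas in compound 2 it sits meta to two methoxy groups. Given the step of a 2.5-fold lower number from compound 1 to compound 2 (0.40 log units; beyond the scatter), a step of similar size is expected in this assay from compound 3 to compound 4, about a 2.5-fold lower number from compound 3 to compound 4 (0.40 log units; beyond the scatter), resting on a single prior example. Compound 4 is therefore estimated at 4000 nM, with a range from 2000 nM to 8000 nM.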

Compound 4, half-maximal inhibitory concentration: 1500 nM
Estimate against measurement, compound 4: 2.7-fold (0.43 log units) above, and the stated range ends above it.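

In this assay 4-methylpiperazin-1-yl in place of piperidin-1-yl gives a 6.7-fold lower number from compound 3 to compound 4 (0.82 log units; beyond the scatter) and so lowers the number on the core of compound 3, as it does on the core of compound 1. The direction of the change therefore carries over between these two cores, but its size does not, and a step read on one core is a poor guide to the exact size on the other. The pair of steps shows that the core matters for the size of the gain, yet it does not show which feature of the core is responsible, nor does it establish a trend with the length of the alkoxy chain, as only methoxy and ethoxy are compared and each step is a single example: the same change on two cores in this assay, a 2.5-fold lower number (0.40 log units; beyond the scatter) from compound 1 to compound 2 and a 6.7-fold lower number (0.82 log units; beyond the scatter) from compound 3 to compound 4, 2.7-fold (0.43 log units) apart, beyond the scatter of two such steps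

Still open, going by these compounds, is whether the gain keeps growing on a core with longer chains, such as two propoxy groups, or how it behaves on a core carrying one methoxy and one ethoxy group. Also open, on these data alone, is how other amines in the same place, such as morpholine or a piperazine with a free ring amine, would compare with 4-methylpiperazin-1-yl on either core.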